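From Ethoxycarbonyl to Acetyl in a Cytotoxicity Series

The source may report more compounds than this note shows. Statements on the series, on what has been measured and on what is new or still open speak of the compounds shown alone.

Compound 1 `Nc1n[nH]c(N)c1/N=N/c1ccncc1`: 4300 nM
Compound 2 `CCOC(=O)n1nc(N)c(/N=N/c2ccc(O)cc2)c1N`: > 100000 nM (a limit of the assay)

In a functional assay on MCF7 cells (Homo sapiens) for cytotoxicity, read by fluorescence, with a stated time of 72 h (a lower number here means a stronger inhibitor, a higher number a weaker inhibitor), compound 1 gives 4300 nM. Compound 2 gives > 100000 nM, which is a limit of the assay and not a number. Compound 2 therefore stands at the limit of > 100000 nM in this assay, at which 1 of the 2 values shown sits.

Compound 3 `CC(=O)n1nc(N)c(/N=N/c2ccc(O)cc2)c1N` keeps the core of compound 2 and alters one group: methyl in place of ethoxy on a carbonyl carbon. In words, this is methyl in place of ethoxy on a carbonyl carbon, or ethoxycarbonyl to acetyl. Going by the values given here, no pair of measured compounds shows what such a change does in this assay. The expectation therefore rests only on compound 2 and its limit of > 100000 nM. No step beyond the scatter is expected in either direction, and the estimated change is an at least 1.4-fold lower number from compound 2 to compound 3 (0.15 log units; that floor lies within the scatter). For compound 3 the expected value is 70000 nM. The estimated range for compound 3 runs from 15000 nM to 200000 nM.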

Compound 3, half-maximal inhibitory concentration: 44900 nM
For compound 3 the middle estimate is 1.6-fold (0.19 log units) above the measured one; the measured number falls inside the stated range.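

In this assay, going by these compounds alone, the change from ethoxycarbonyl to acetyl, on a carbonyl carbon whose other neighbour is an aromatic nitrogen, gives the first reading of this position: an at least 2.2-fold lower number from compound 2 to compound 3 (0.34 log units; beyond the scatter). Compound 2 gives > 100000 nM, which is a limit of the assay and not a number. From the compounds shown here alone, the step therefore fixes only a lower bound on the size of this change, and its true size stays unknown, because one end of it rests on a limit: the limit of > 100000 nM in this assay, at which 1 of the 3 values shown sits.

Going by these compounds, what an amine or a longer chain in place of the methyl on this carbonyl carbon would do in this assay stays open. Compound 1 differs from compound 3 in more than one place, so the compounds shown do not tell how the acetyl group bears on the gap between them.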